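The source may report more compounds than this note shows. Statements on the series, on what has been measured and on what is new or still open speak of the compounds shown alone.

Of the compounds shown here, three have so far been measured in a functional assay on M21 cells (Homo sapiens) for antiproliferative activity, read by sulforhodamine B assay, with a stated time of 48 h; on this read-out higher numbers stand for weaker inhibition and lower numbers for stronger inhibition. Compound 1 `CC(C)c1ccccc1OS(=O)(=O)c1cccc(NC(=O)CCl)c1` gives 3900 nM. Compound 2 `CC(C)C(=O)Nc1ccc(S(=O)(=O)Oc2ccccc2C(C)C)cc1` gives 11000 nM, and compound 3 `CC(C)C(=O)Nc1ccc(S(=O)(=O)Oc2ccccc2I)cc1` gives 13000 nM. On these numbers compound 3 stands highest of the three: its nearest neighbour is compound 2, whose number lies within the scatter of it, while compound 1 lies beyond the scatter with the lower number. Among the compounds with values here, the only single-place step among the measured compounds is a 1.2-fold higher number from compound 2 to compound 3 (0.07 log units; within the scatter), which put iodo in place of isopropyl on an aromatic carbon and left the read-out essentially where it was.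

Compound 4 `O=C(NCC1CCCC1)Nc1ccc(S(=O)(=O)Oc2ccccc2I)cc1` differs from compound 3 in a different place: (cyclopentylmethyl)amino in place of isopropyl on a carbonyl carbon. Within the data shown here, no measured step touches this carbonyl carbon. Compound 1 also carries a different group on its amide, but it differs from compound 3 in more than one place, so only the two values of compound 1 and compound 3 can be set side by side, and they sit a good way apart. With nothing bearing directly on the change, the expected step in this assay is none beyond the scatter, though a wide range must be allowed. Compound 4 is therefore estimated at 10000 nM, within 3500 nM to 30000 nM, which means an expected 1.3-fold lower number from compound 3 to compound 4 (0.11 log units; within the scatter).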

Compound 4, half-maximal inhibitory concentration: 7600 nM
Beside the measured number, compound 4's estimate is 1.3-fold (0.12 log units) above it; measured number inside the range.
By their numbers in this assay, from the lowest: compounds 1, 4, 2 and 3 (each within the scatter of the next, the first and the last beyond it).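

In this assay, within the data shown here, the first change at this carbonyl carbon gives a 1.7-fold lower number from compound 3 to compound 4 (0.23 log units; within the scatter) and so stays within the scatter. Replacing isopropyl with (cyclopentylmethyl)amino, which turns isopropylcarbonyl into (cyclopentylmethyl)carbamoyl, brings a five-membered non-aromatic ring of carbon only and a hydrogen-bond donor to this place, yet the read-out does not separate compound 4 from compound 3. Among these compounds, the earlier step, iodo in place of isopropyl, concerned an aromatic carbon, so this is the first sign that the carbonyl substituent can also change this much without a step beyond the scatter, and nothing available explains the result.

The compounds shown leave open whether a carboxylic acid, a basic amine or a longer alkyl chain on this carbonyl carbon would move the number beyond the scatter. They also leave open what the ring and the amine nitrogen each contribute, since the two entered together in a single change, so a cyclopentylmethyl group joined directly to the carbonyl carbon, without that nitrogen, would be needed to separate them.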